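This account rests on a few compounds, and the source may have more. Where it says the series, first, only, none or still open, it means among the compounds named here.

Measured in an ADME assay on liver for metabolic stability, with Liver microsome (Homo sapiens) as the target, read by LC-MS, using microsomes (a higher number here means faster removal of the compound, a lower number slower removal), limits only:
- Compound 1 `O=C(NCc1cc(Cl)ccc1-n1cnnn1)[C@@H]1C[C@@H]2C[C@@H]2N1C(=O)[C@H](O)Cn1cccn1` gives < 12 mL.min-1.g-1 as a limit.
- Compound 2 `O=C(NCc1cc(Cl)ccc1-n1cnnn1)[C@@H]1C[C@@H]2C[C@@H]2N1C(=O)[C@H](O)c1ccccc1F` gives < 12 mL.min-1.g-1 as a limit.

Compound 2 therefore has no number, and both compounds sit at one floor (the limit of < 12 mL.min-1.g-1 in this assay, at which 2 of the 2 values shown sit). Compound 3 `COC(C)(C)[C@@H](O)C(=O)N1[C@H](C(=O)NCc2cc(Cl)ccc2-n2cnnn2)C[C@@H]2C[C@@H]21` follows from compound 2 through 1-methoxy-1-methylethyl in place of 2-fluorophenyl on a saturated chain carbon bound to a carbonyl carbon and an oxygen on a saturated carbon (1-methoxy-1-methylethyl in place of 2-fluorophenyl). Among the measured compounds shown here, the one measured step at this place is a step that the two limits leave unreadable from compound 1 to compound 2 and it offers no size to carry over. The limit of compound 2 at < 12 mL.min-1.g-1 is the only anchor. The expected step in this assay is a step that the limit leaves unreadable from compound 2 to compound 3 and nothing beyond the scatter is expected, in either direction. Compound 3 is estimated at 10 mL.min-1.g-1 with a range from 6 mL.min-1.g-1 to 20 mL.min-1.g-1 and may well come out only as a limit.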

Compound 3, intrinsic clearance in microsomes: 40 mL.min-1.g-1
Beside the measured number, compound 3's estimate is 4.0-fold (0.60 log units) below it; the whole stated range lies below it.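

In this assay, this position on a saturated chain carbon can change the read-out: 1-methoxy-1-methylethyl in place of 2-fluorophenyl gives an at least 3.3-fold higher number from compound 2 to compound 3 (0.52 log units; beyond the scatter) and in place of (1H-pyrazol-1-yl)methyl gives an at least 3.3-fold higher number from compound 1 to compound 3 (0.52 log units; beyond the scatter). The earlier pair could not show this. Both sizes are only lower bounds because compound 1 and compound 2 are limits: the limit of < 12 mL.min-1.g-1 in this assay, at which 2 of the 3 values shown sit.

The compounds shown do not separate the methoxy group from the two methyl groups of the entering substituent. From the compounds shown here alone, a tert-butyl group or a straight 2-methoxyethyl chain at this place remains open.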